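Compound 4: a carboxy-bearing amino group on the carbonyl carbon

The source may hold more compounds than are shown below. What is called first, only, known or untested is meant among the compounds shown, and "the series" means these compounds.

In an ADME assay on L02 cells (Homo sapiens) for cytotoxicity, read by MTT assay, with a stated time of 48 h (a lower number here means a stronger inhibitor, a higher number a weaker inhibitor), compound 1 `CCn1c(C(=O)NCCCN(C)C)ccc1C(CC)(CC)c1ccc(OCC(O)C(C)(C)C)c(C)c1` gives 470 nM, compound 2 `CCN(CC)CCCNC(=O)c1ccc(C(CC)(CC)c2ccc(OCC(O)C(C)(C)C)c(C)c2)n1CC` gives 2500 nM and compound 3 `C#CC(C)OC(=O)c1ccc(C(CC)(CC)c2ccc(OCC(O)C(C)(C)C)c(C)c2)n1CC` gives 23700 nM. Compound 3 therefore has the highest number of the three, making it the weakest inhibitor measured so far.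

Compound 4 `CC[C@@H](C)[C@H](NC(=O)c1ccc(C(CC)(CC)c2ccc(OCC(O)C(C)(C)C)c(C)c2)n1CC)C(=O)O` keeps the shared core but carries (1-carboxy-2-methylbutyl)amino in place of (1-methylprop-2-yn-1-yl)oxy on a carbonyl carbon.

Two measured steps change the group at this same carbonyl carbon. One is large, a 50-fold higher number from compound 1 to compound 3 (1.70 log units; beyond the scatter), and the other modest, a 9.5-fold higher number from compound 2 to compound 3 (0.98 log units; beyond the scatter). A third, a 5.3-fold higher number from compound 1 to compound 2 (0.73 log units; beyond the scatter), shows that changing only the end of the chain can also move the number. Like compounds 1 and 2, compound 4 has an amino group on the carbonyl carbon, but it lacks their dimethylamino and diethylamino groups. For the measured compounds named here, no measured compound carries a carboxy group, so these steps are only a weak guide.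

A return to the lower numbers of compounds 1 and 2 is not expected. In this assay, no change beyond the scatter is expected, with a slight lean upward: the estimated step is a 1.3-fold higher number from compound 3 to compound 4 (0.10 log units; within the scatter). For compound 4 the estimated value is 30000 nM, with an expected range from 10000 nM to 90000 nM.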

Compound 4, half-maximal inhibitory concentration: 1400 nM
Compound 4: the middle estimate sits 21-fold (1.33 log units) above what was measured, outside the stated range (below it).
By their numbers in this assay, from the lowest: compound 1; then compounds 4 and 2 (each within the scatter of the next); then compound 3.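

In this assay the step of a 17-fold lower number from compound 3 to compound 4 (1.23 log units; beyond the scatter) means that all three compounds with an amino group on this carbonyl carbon now have lower numbers than the one with (1-methylprop-2-yn-1-yl)oxy, and this holds even though compound 4 has neither the dimethylamino nor the diethylamino end of the earlier chains. On the amide-type nitrogen, 1-carboxy-2-methylbutyl cannot be told apart from 3-(diethylamino)propyl, given a 1.8-fold lower number from compound 2 to compound 4 (0.25 log units; within the scatter), while a 3.0-fold higher number from compound 1 to compound 4 (0.47 log units; beyond the scatter) leaves compound 1 with the lowest number of the four. Nothing available here accounts for these differences in cytotoxicity.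

The compounds shown leave open what an amide carrying a plain alkyl chain, with neither an amine nor a carboxylic acid, would give, and so whether the amide link alone goes with the lower numbers. Also open, on these data alone, are how a longer chain carrying the carboxylic acid would compare, and whether the two defined stereocentres of the 1-carboxy-2-methylbutyl group matter.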